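Swapping the Aryl Group on the Amide Nitrogen

The compounds below may be only part of what the source reports. "The series", "measured", "known", "first", "only" and "open" are said of these compounds alone.

Compound 1 `O=C(CCC(=O)OCCCCCCSc1ccc([N+](=O)[O-])c2nonc12)Nc1ccccc1F` gives 350 nM in an assay on isolated protein for inhibition of glutathione S-transferase Mu 2 (Homo sapiens), with a stated time of 10 min; a lower number here means a stronger inhibitor, a higher number a weaker inhibitor.
Compound 2 `Cc1ccccc1NC(=O)CCC(=O)OCCCCCCSc1ccc([N+](=O)[O-])c2nonc12` gives 440 nM in this assay.

Within the data shown here, compound 2 holds the higher of the two numbers, with compound 1 as its only neighbour. Among the measured compounds shown here, the single measured step is a 1.3-fold higher number from compound 1 to compound 2 (0.10 log units; within the scatter). Compound 3 `O=C(CCC(=O)OCCCCCCSc1ccc([N+](=O)[O-])c2nonc12)Nc1ccc(F)c(Cl)c1` differs from compound 2 by 3-chloro-4-fluorophenyl in place of 2-methylphenyl on an amide-type nitrogen. For the measured compounds named here, no measured step reproduces this exchange; the one step that alters the aryl group, methyl in place of fluoro on an aromatic carbon, stayed within the scatter, so such aryl changes have so far moved the number little. The step of a 1.1-fold lower number from compound 2 to compound 3 (0.04 log units; within the scatter) is therefore expected to remain within the scatter. Compound 3 is estimated at 400 nM, within 200 nM to 800 nM.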

Compound 3, half-maximal inhibitory concentration: 470 nM
Beside the measured number, compound 3's estimate is 1.2-fold (0.07 log units) below it, within the range that was stated.
By their numbers in this assay, from the lowest: compounds 1, 2 and 3 (each within the scatter of the next).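

The exchange of 2-methylphenyl for 3-chloro-4-fluorophenyl on the amide-type nitrogen gives a 1.1-fold higher number from compound 2 to compound 3 (0.03 log units; within the scatter) in this assay, and the exchange of 2-fluorophenyl for the same group gives a 1.3-fold higher number from compound 1 to compound 3 (0.13 log units; within the scatter) in that assay. At this position, then, a phenyl carrying both chlorine and fluorine stays within the scatter of the two phenyls carrying a single group. Nothing available bears on the reason for this result. On these data alone, it remains open whether an aminophenyl, a carboxyphenyl or a simple alkyl chain on this nitrogen would move the number beyond the scatter.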